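A few compounds are considered here, and "the series" means these few. Any claim that something is new, unique, unknown or untested is made for them only; others in the source may bear on it.

Working notes on a short dichloroacetamide series tested in a functional assay on Bel-7402 cells (Homo sapiens) for antiproliferative activity, read by MTT assay, with a stated time of 72 h; a higher number here means a weaker inhibitor, a lower number a stronger inhibitor.

Four anilides share the same dichloroacetyl amide core and differ only in the single substituent on the aromatic ring. Compound 1 `Cc1ccccc1NC(=O)C(Cl)Cl` carries a methyl group; for compound 1 the outcome in this assay stands as "not determined" (no result reported). Compound 2 `O=C(Nc1ccccc1F)C(Cl)Cl` carries a fluoro group; for compound 2 the outcome in this assay likewise stands as "not determined" (no result reported). Compound 3 `O=C(Nc1cccc(Cl)c1)C(Cl)Cl` carries a chloro group, and in this assay compound 3 gives 44500 nM. Among the compounds with values here, compound 3 therefore holds the only number available in the set, so there is no comparison point among measured compounds and no reference for how a change on the ring moves the read-out.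

Compound 4 `COc1cccc(NC(=O)C(Cl)Cl)c1` is the next member to be measured. Relative to compound 3 the change is methoxy in place of chloro on an aromatic carbon. Within the data shown here, with no measured step in hand, a small shift toward a weaker inhibitor is expected, of a size a 1.3-fold higher number from compound 3 to compound 4 (0.13 log units; within the scatter) that may not clear the scatter. For compound 4 the estimate in this assay is 60000 nM, with a plausible range from 20000 nM to 180000 nM.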

Compound 4, half-maximal inhibitory concentration: 54800 nM
Estimate against measurement, compound 4: 1.1-fold (0.04 log units) above; measured number inside the range.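

In this assay, within the data shown here, the exchange of methoxy in place of chloro on an aromatic carbon, meta to a group of 6 heavy atoms, gives the first readable step, a 1.2-fold higher number from compound 3 to compound 4 (0.09 log units; within the scatter) and this step does not separate the two compounds. At this position, then, one heavy atom of chlorine and the two heavy atoms of methoxy, with the one hydrogen-bond acceptor that methoxy brings, read alike within the scatter, and that holds for this single pair only. No measurement on these compounds speaks to the reason for this outcome.

Compounds 1 and 2 carry no number, so steps involving their methyl and fluoro groups cannot be read. From the compounds shown here alone, whether a different kind of group on this aromatic carbon, such as an amine, a carboxylic acid or a longer chain, would move the number in this assay beyond the scatter remains open, since one step within the scatter does not show how far the read-out responds to change here.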